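Alkyl ether chain length in a eugenol-derived series

This account rests on a few compounds, and the source may have more. Where it says the series, first, only, none or still open, it means among the compounds named here.

Measured compounds:
- compound 1, `C=CCc1cc(OC)c(OC(C)C(OCCCCCCCCCC)c2ccc(O)c(OC)c2)c(OC)c1`, 66 nM
- compound 2, `C=CCc1cc(OC)c(O[C@@H](C)[C@H](OCC)c2ccc(O)c(OC)c2)c(OC)c1`, 1130 nM

In an assay on HEK293 cells for agonist activity at transient receptor potential cation channel subfamily M member 8 (Homo sapiens), read by fluorescence and calcium flux, with a stated time of 5 min (a lower number here means that less compound is needed, a higher number that more compound is needed for the effect), compound 1 gives 66 nM, the lowest of the two numbers recorded. The nearest neighbour is compound 2, which in this assay gives 1130 nM; compound 2 carries an ethyl ether in place of the decyl ether and also has defined stereocentres, so the gap between the two values is not a single-change step, and no cause is attached to it.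

Compound 3, `C=CCc1cc(OC)c(OC(C)C(OCCCCCC)c2ccc(O)c(OC)c2)c(OC)c1`, is not yet measured. It differs from compound 1 by hydrogen in place of butyl on a saturated chain carbon, six bonds along the chain from an oxygen on a saturated carbon, which cuts the decyl ether back to a hexyl ether on the same core. The two measured values together suggest that a shorter chain at this position runs toward a higher number, but compound 3 keeps most of the chain. The step from compound 1 to compound 3 is therefore expected to be modest, toward a higher number, and it may not clear the scatter: a 2.3-fold higher number from compound 1 to compound 3 (0.36 log units; beyond the scatter). Compound 3 is estimated at 150 nM, with a range from 50 nM to 500 nM in this assay.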

Compound 3, half-maximal effective concentration: 329 nM
Beside the measured number, compound 3's estimate is 2.2-fold (0.34 log units) below it; measured number inside the range.
By their numbers in this assay, from the lowest: compound 1; then compound 3; then compound 2.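

In this assay, the series now has its first comparison that differs in one place: hydrogen in place of butyl on a saturated chain carbon, six bonds along the chain from an oxygen on a saturated carbon, gives a 5.0-fold higher number from compound 1 to compound 3 (0.70 log units; beyond the scatter). Ether chain length therefore counts on its own at this position of the shared core, with no difference in defined stereocentres entering the comparison, which the values of compound 1 and compound 2 could not show. Nothing available bears on why the hexyl ether needs more compound than the decyl ether.

On these data alone, with only the decyl and hexyl ethers compared in one place, it remains open whether a longer chain such as dodecyl would continue this direction, or whether a chain ending in an amine or a carboxylic acid would follow it. The contribution of the defined stereocentres in compound 2 also cannot be read apart from that of its ethyl ether.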